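The compounds below may be only part of what the source reports. "The series", "measured", "known", "first", "only" and "open" are said of these compounds alone.

Compound 1 `CCCN(CC1CCOC1)C(=O)c1ccc2oc(NCc3cccc(Cl)c3)nc2c1`: 214 nM
Compound 2 `CCCN(CC1CCOC1)C(=O)c1cc(OC)c2oc(NCc3cccc(Cl)c3)nc2c1`: 12 nM

Both numbers come from an assay on isolated protein for inhibition of thyroid hormone receptor beta (Homo sapiens), read by fluorescence, with a stated time of 30 min; a higher number here means a weaker inhibitor, a lower number a stronger inhibitor. For the measured compounds named here, compound 2 has the lowest number of the two, and the one measured step is large: an 18-fold lower number from compound 1 to compound 2 (1.25 log units; beyond the scatter). Compound 3 `CCC1CC(O)C(C)CN1C(=O)c1cc(OC)c2oc(NCc3cccc(Cl)c3)nc2c1` is not yet measured. Going by the values given here, it keeps the methoxy and the rest of compound 2 and changes only the group on the carbonyl carbon: 2-ethyl-4-hydroxy-5-methylpiperidin-1-yl in place of ((oxolan-3-yl)methyl)(propyl)amino on a carbonyl carbon The measured step concerns a methoxy on an aromatic carbon, not this carbonyl, so no measured step bears on the change. Without a comparable example, no step beyond the scatter is expected in this assay in either direction, though the uncertainty is wide. Compound 3 is estimated at 25 nM, between 6 nM and 120 nM. This expectation means a 2.1-fold higher number from compound 2 to compound 3 (0.32 log units; beyond the scatter).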

Compound 3, half-maximal inhibitory concentration: 13 nM
Compound 3: middle estimate off by 1.9-fold (0.28 log units), on the high side; low and high end bracket the measured number.
By their numbers in this assay, from the lowest: compounds 2 and 3 (each within the scatter of the next); then compound 1.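

In this assay, placing 2-ethyl-4-hydroxy-5-methylpiperidin-1-yl in place of ((oxolan-3-yl)methyl)(propyl)amino on the carbonyl carbon gives a 1.1-fold higher number from compound 2 to compound 3 (0.03 log units; within the scatter). For this pair, then, a different group with the same heavy-atom count, a six-membered ring and an added hydrogen-bond donor leaves the number within the scatter, with the methoxy kept. Nothing available explains this result.

The compounds shown leave open whether the hydroxy matters, which a carboxylic acid or an amine in its place could test. On these data alone, it is also open whether this group gives a similar result on the core of compound 1, which has no methoxy.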